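Methyl to Isopropyl: Estimating Compound 4

A few compounds are considered here, and "the series" means these few. Any claim that something is new, unique, unknown or untested is made for them only; others in the source may bear on it.

Measured compounds:
Compound 1 `Cc1ccccc1Nc1nc(Nc2ccccc2)ncc1Cl` gives > 100000 nM in a functional assay on Jurkat cells (Homo sapiens) for inhibition, read by CCK-8 assay, with a stated time of 48 h (a higher number here means a weaker inhibitor of growth, a lower number a stronger inhibitor of growth), which is a limit of the assay rather than a number.
Compound 2 `Cc1ccccc1Nc1nc(Nc2ccccn2)ncc1Cl` gives 20100 nM in this assay.
Compound 3 `Cc1ccccc1Nc1nc(Nc2ccc(N3CCN(C)CC3)cn2)ncc1Cl` gives 8080 nM in this assay.

Compound 3 has the lowest number of the three; its nearest neighbour is compound 2, and that gap is a 2.5-fold lower number from compound 2 to compound 3 (0.40 log units; beyond the scatter), which is beyond the scatter. The value of compound 1 is a limit (the limit of > 100000 nM in this assay, at which 1 of the 3 values shown sits), so only the direction of an at least 4.9-fold lower number from compound 1 to compound 2 (0.69 log units; beyond the scatter) is known there.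

Compound 4 `CC(C)c1ccccc1Nc1nc(Nc2ccc(N3CCN(C)CC3)cn2)ncc1Cl` differs from compound 3 in one place: isopropyl in place of methyl on an aromatic carbon. Neither of the measured steps touches this part of the molecule. The step from compound 1 to compound 2 changed the ring on the other nitrogen, and the step from compound 2 to compound 3 added a group to that same ring. Both steps were at least modest and both lowered the number, but they say nothing about exchanging methyl for isopropyl on the carbon-only ring. Among the compounds with values here, with no comparable step in hand, the change is expected to leave the number where it is, within the usual scatter or close to it, and the estimated step is a 1.2-fold lower number from compound 3 to compound 4 (0.06 log units; within the scatter). Compound 4 is therefore expected to give about 7000 nM in this assay, with a range from 2500 nM to 20000 nM.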

Compound 4, concentration for 50% growth inhibition: 5140 nM
Compound 4: the middle estimate sits 1.4-fold (0.13 log units) above what was measured, and the stated range covers the measured number.
By their numbers in this assay, from the lowest: compounds 4 and 3 (each within the scatter of the next); then compound 2. At a limit, above all of these: compound 1.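

Compound 4 is the only compound shown that alters the carbon-only ring, since the earlier steps all concerned the ring on the other nitrogen. At this position, on an aromatic carbon and ortho to a large group, methyl gives way to isopropyl, which has 3 heavy atoms against 1, and in this assay the result is a 1.6-fold lower number from compound 3 to compound 4 (0.20 log units; within the scatter), so the two compounds cannot be told apart and the larger group costs nothing measurable in growth inhibition. The information available offers no explanation for this result.

On these data alone, it remains open how far this tolerance extends, for instance whether a longer chain, an amine or a carboxylic acid at the same position would leave the number where it stands or move it beyond the scatter. It is also open whether exchanging methyl for isopropyl would read the same way in compound 2, which lacks the 4-methylpiperazin-1-yl group, since the step shown here comes from a single pair of compounds.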